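The compounds below may be only part of what the source reports. "The series", "measured", "known", "first", "only" and "open" are said of these compounds alone.

Among the compounds with values here, compound 1 `c1ccc(C(/N=C2\CCCCN2)C2CC2)cc1` and compound 2 `Cc1ccc(C(/N=C2\CCCCCCCN2)C2CC2)c(C)c1` are the two measured members so far. In a functional assay on the whole organism (plasma, strain Sprague-Dawley) with Rattus norvegicus as the target, with a stated time of 2 h, at a dose of 25 mg/kg by the oral route (on this read-out higher numbers stand for a stronger effect at the one dose given and lower numbers for a weaker effect), compound 1 gives 23%, and compound 2 gives 37%. Compound 1 thus stands lowest of the two numbers, with compound 2 above it by more than the usual scatter. Within the data shown here, no pair of measured compounds differs in a single place, so no measured step guides the next change. Compound 3 `c1ccc(C(/N=C2\CCCCN2)c2ccco2)cc1` is not yet measured. It differs from compound 1 in one place: furan-2-yl in place of cyclopropyl on a saturated chain carbon bound to an aromatic carbon and a double-bonded nitrogen. Nothing measured bears on furan-2-yl against cyclopropyl on that saturated chain carbon. No step beyond the scatter is therefore expected in this assay, in either direction. The expected step is a number 2 percentage points higher from compound 1 to compound 3 (within the scatter). Compound 3 is estimated at 25% in this assay, with an expected range from 5% to 50%, kept wide for want of any guiding step.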

Compound 3, a percentage reported as inhibition, in the whole organism at one dose (the size of the read-out at that dose, not a potency): 10%
For compound 3 the middle estimate is 15 percentage points above the measured one; the range from low to high includes it.
By their numbers in this assay, from the lowest: compound 3; then compound 1; then compound 2.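

In this assay, furan-2-yl in place of cyclopropyl on a saturated chain carbon bound to an aromatic carbon and a double-bonded nitrogen gives a number 13 percentage points lower from compound 1 to compound 3 (beyond the scatter). Within the data shown here, this is the first single-place step, and it shows that the group on this carbon can change the read-out at the one dose given, with cyclopropyl standing above furan-2-yl on the core of compound 1. Nothing at hand bears on what lies behind this step.

On these data alone, whether the same change gives a similar step on the core of compound 2 remains open, since compound 1 and compound 2 differ in more than one place. Also open, as far as these compounds go, is how a saturated ring such as cyclopentyl, or a branched chain such as isopropyl, would read on this carbon.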